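Aryl variation on the triazole of the shared core

The compounds below may be only part of what the source reports. "The series", "measured", "known", "first", "only" and "open" are said of these compounds alone.

Measured compounds in a functional assay on BMDM cells (Mus musculus, strain C57BL/6) for inhibition, with a stated time of 2 days; on this read-out lower numbers stand for stronger inhibition and higher numbers for weaker inhibition:
- compound 1, `Cc1csc(NC(=O)Cn2cc(-c3cccc(N)c3)nn2)n1`, 250 nM
- compound 2, `Cc1csc(NC(=O)Cn2cc(-c3ccncc3)nn2)n1`, 100 nM
- compound 3, `Cc1csc(NC(=O)Cn2cc(-c3ccc(F)cc3)nn2)n1`, 250 nM

Compound 3 sits level with compound 1 at the digits printed, and the two together give the highest numbers of the three in this assay; the step of no change at the digits printed from compound 1 to compound 3 (within the scatter) is within the scatter. Compound 2 stands apart: a 2.5-fold higher number from compound 2 to compound 3 (0.40 log units; beyond the scatter) is beyond the scatter, as is a 2.5-fold lower number from compound 1 to compound 2 (0.40 log units; beyond the scatter), though both are modest.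

Compound 4, `Cc1csc(NC(=O)Cn2cc(-c3cccs3)nn2)n1`, is not yet measured. It differs from compound 3 in one place: thiophen-2-yl in place of 4-fluorophenyl on an aromatic carbon.

Among the compounds with values here, no measured step swaps a six-membered ring for a five-membered one, so none bears on this change directly. What the three steps do show is that exchanging the aryl ring at this position moved this assay by at most a modest amount, and in one case not at all. On that basis a step of similar size or smaller is expected for compound 4, with direction uncertain. For compound 4 the expected middle case is a slightly lower number, an estimated 1.4-fold lower number from compound 3 to compound 4 (0.14 log units; within the scatter), because compound 2 with a ring heteroatom gave 100 nM. Compound 4 is therefore estimated at 180 nM in this assay, with a range from 70 nM to 500 nM.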

Compound 4, half-maximal inhibitory concentration: 40 nM
Beside the measured number, compound 4's estimate is 4.5-fold (0.65 log units) above it; the whole stated range lies above it.
By their numbers in this assay, from the lowest: compound 4; then compound 2; then compounds 1 and 3 (each within the scatter of the next).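

The thiophen-2-yl ring is the only five-membered aromatic ring at this position on the shared core, and in this assay it produces the largest steps in the series: a 6.3-fold lower number from compound 3 to compound 4 (0.80 log units; beyond the scatter) and a 6.3-fold lower number from compound 1 to compound 4 (0.80 log units; beyond the scatter) both exceed anything seen among the six-membered rings. The earlier compounds shown here spanned only a modest range, with pyridin-4-yl at the low end, but a 2.5-fold lower number from compound 2 to compound 4 (0.40 log units; beyond the scatter) places compound 4 clearly below that as well, giving it the lowest number of the four, with every step to the others beyond the scatter. The position therefore responds more strongly to the choice of ring than the three six-membered rings alone suggested, although no available measurement explains the result or separates the change in ring size from the ring sulfur.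

Furan-2-yl and thiophen-3-yl would test whether the low number depends on the sulfur-containing ring or on its point of attachment, and an unsubstituted phenyl would give a plain six-membered comparator. From the compounds shown here alone, whether a methyl or chloro group on the thiophene ring preserves the number also remains open.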